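The source may hold more compounds than are shown below. What is called first, only, known or untested is meant among the compounds shown, and "the series" means these compounds.

The measured compounds are three:
compound 1, `CC(C)CCn1cnc2c(Nc3ccc(Cl)cc3)nc(N[C@H]3CC[C@H](N)CC3)nc21`, which gives 1800 nM in a functional assay on K562 cells (Homo sapiens) for inhibition, read by fluorescence, with a stated time of 72 h; on this read-out higher numbers stand for weaker inhibition of growth and lower numbers for stronger inhibition of growth;
compound 2, `CC(C)CCn1cnc2c(Nc3cccc(O)c3)nc(N[C@H]3CC[C@H](N)CC3)nc21`, which gives 7600 nM in this assay;
compound 3, `CC(C)CCn1cnc2c(Nc3ccccc3)nc(N[C@H]3CC[C@H](N)CC3)nc21`, which gives 3500 nM in this assay.

Compound 1 has the lowest number of the three. Its nearest neighbour is compound 3, and the step of a 1.9-fold higher number from compound 1 to compound 3 (0.29 log units; within the scatter) lies within the scatter, so the two cannot be ordered on this read-out. Its furthest neighbour is compound 2, and the step of a 4.2-fold higher number from compound 1 to compound 2 (0.63 log units; beyond the scatter) is beyond the scatter, as is the step of a 2.2-fold lower number from compound 2 to compound 3 (0.34 log units; beyond the scatter).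

The unmeasured compound 4, `CCCCCCn1cnc2c(Nc3ccc(Cl)cc3)nc(N[C@H]3CC[C@H](N)CC3)nc21`, differs from compound 1 by butyl in place of isopropyl on a saturated chain carbon, two bonds along the chain from an aromatic nitrogen. Among the measured compounds shown here, all three measured steps concern the group on a nitrogen on an aromatic ring; none of them touches the saturated chain where this change sits, so no measured step bears on it directly. With no comparison to draw on, the expectation for compound 4 is a step of no more than the scatter, a 1.1-fold higher number from compound 1 to compound 4 (0.02 log units; within the scatter), in either direction. Compound 4 is therefore estimated at 1900 nM in this assay, with a range from 700 nM to 5000 nM, the width of that range reflecting the absence of any guiding step.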

Compound 4, concentration for 50% growth inhibition: 2100 nM
The estimate for compound 4 lay 1.1-fold (0.04 log units) below the measured number; low and high end bracket the measured number.
By their numbers in this assay, from the lowest: compounds 1, 4 and 3 (each within the scatter of the next); then compound 2.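

Among the compounds shown here, the first comparison at the saturated chain comes from the exchange of isopropyl for butyl, which can also be read as isopentyl to hexyl, and in this assay it gives a 1.2-fold higher number from compound 1 to compound 4 (0.07 log units; within the scatter), so the two compounds cannot be told apart on this read-out. The earlier steps shown here concerned only the group on a nitrogen on an aromatic ring, where a 4.2-fold higher number from compound 1 to compound 2 (0.63 log units; beyond the scatter) showed that a single exchange there can go beyond the scatter, whereas this one exchange at the chain does not. No measurement is available that would explain this result.

The compounds shown leave open whether a longer chain, a cycloalkyl group such as cyclohexyl, or a chain ending in an amine or a carboxylic acid would also stay within the scatter of compound 1. They also leave open whether the exchange of isopentyl for hexyl would give the same result with phenyl or 3-hydroxyphenyl in place of 4-chlorophenyl on the aromatic-ring nitrogen.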